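The source may report more compounds than this note shows. Statements on the series, on what has been measured and on what is new or still open speak of the compounds shown alone.

Three compounds share one core and differ only in the pattern of groups on the aromatic ring. In a functional assay on M14 cells (Homo sapiens) for antiproliferative activity, with a stated time of 72 h (on this read-out lower numbers stand for stronger inhibition and higher numbers for weaker inhibition), compound 1 `C=CC[C@H]1C[C@]2([C@H](C)Cc3ccc(OC)c(OC)c3)OCOC2=CC1=O` gives 300 nM, compound 2 `C=CC[C@H]1C[C@]2([C@@H](C)Cc3cccc(OC)c3)OCOC2=CC1=O` gives 8800 nM, and compound 3 `C=CC[C@H]1C[C@]2([C@@H](C)Cc3ccc(OC)c(C)c3)OCOC2=CC1=O` gives 410 nM. Compound 3 thus stands second highest of the three numbers; its nearest neighbour is compound 1, whose number is within the scatter of its own, while its furthest is compound 2, whose number lies well beyond the scatter.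

Compound 4 `C=CC[C@H]1C[C@]2([C@@H](C)Cc3ccc(OC)c(F)c3)OCOC2=CC1=O` has not yet been tested. It differs from compound 3 by fluoro in place of methyl on an aromatic carbon, a change on an aromatic carbon ortho to a methoxy group. Among the compounds with values here, no measured pair shows exactly this swap. Since compound 1 and compound 3 carry different groups at this position yet give numbers within the scatter of each other, the author expects the step from compound 3 to compound 4 in this assay to be small, likely none beyond the scatter, perhaps a slight rise: a 1.2-fold higher number from compound 3 to compound 4 (0.09 log units; within the scatter). Compound 4 is therefore estimated at 500 nM, within a range from 200 nM to 1500 nM.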

Compound 4, half-maximal inhibitory concentration: 8 nM
Estimate against measurement, compound 4: 63-fold (1.80 log units) above, and the stated range ends above it.
By their numbers in this assay, from the lowest: compound 4; then compounds 1 and 3 (each within the scatter of the next); then compound 2.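

In this assay, fluoro in place of methyl on an aromatic carbon ortho to a methoxy group gives a 51-fold lower number from compound 3 to compound 4 (1.71 log units; beyond the scatter), a step beyond the scatter. Within the data shown here, the leaving and entering groups each count one heavy atom and neither brings a hydrogen-bond donor or acceptor, so this position responds strongly to an exchange that leaves those counts unchanged, which no earlier pair could show, as none differed in one place only. The data shown offer no measurement that explains the size of this step.

As far as these compounds go, it remains open whether chloro, hydroxy or an amine at this position would give a number closer to that of compound 4 or of compound 3. From the compounds shown here alone, it is equally open whether the step would keep its size if the neighbouring methoxy group gave way to ethoxy.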